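Swapping ethoxy for trifluoromethyl on a urea series

The compounds below may be only part of what the source reports. "The series", "measured", "known", "first", "only" and "open" are said of these compounds alone.

The three measured compounds share one core, a chloropyrazine joined through a benzylamine to a diaryl urea, and differ only in the aryl group on the far urea nitrogen. Compound 1 `O=C(Nc1cccc(CNc2nccnc2Cl)c1)Nc1ccccc1Cl` gives 7130 nM in a functional assay on MGC-803 cells (Homo sapiens) for antiproliferative activity, read by MTT assay, with a stated time of 48 h; a lower number here means a stronger inhibitor, a higher number a weaker inhibitor. Compound 2 `CCOc1ccc(NC(=O)Nc2cccc(CNc3nccnc3Cl)c2)cc1` gives 7240 nM, and compound 3 `O=C(Nc1cccc(CNc2nccnc2Cl)c1)Nc1ccc(Cl)cc1Cl` gives 6430 nM. Compound 2 sits within the scatter of both neighbours: the step of a 1.0-fold higher number from compound 1 to compound 2 (0.01 log units; within the scatter) and the step of a 1.1-fold lower number from compound 2 to compound 3 (0.05 log units; within the scatter) are both too small to count, as is the step of a 1.1-fold lower number from compound 1 to compound 3 (0.04 log units; within the scatter).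

Compound 4 `O=C(Nc1ccc(C(F)(F)F)cc1)Nc1cccc(CNc2nccnc2Cl)c1` is not yet measured. It differs from compound 2 by trifluoromethyl in place of ethoxy on an aromatic carbon. For the measured compounds named here, the steps that bear on this change are those that swapped the aryl group on the same urea nitrogen, and none of them moved the number beyond the scatter. A step of no real size is therefore expected here too, with a 1.0-fold lower number from compound 2 to compound 4 (0.01 log units; within the scatter) as the expected outcome. Compound 4 is estimated at 7000 nM, with a likely range from 3500 nM to 14000 nM.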

Compound 4, half-maximal inhibitory concentration: 6910 nM
For compound 4 the middle estimate is 1.0-fold (0.01 log units) above the measured one; the measured number falls inside the stated range.
By their numbers in this assay, from the lowest: compounds 3, 4, 1 and 2 (each within the scatter of the next).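

Earlier steps either exchanged a whole aryl group or put chloro in place of hydrogen; here one group directly replaces another on an aromatic carbon, para to a large group, and in this assay this gives a 1.0-fold lower number from compound 2 to compound 4 (0.02 log units; within the scatter). Ethoxy, with its hydrogen-bond acceptor, leaves and trifluoromethyl, with none, enters, yet the step stays within the scatter, so keeping that acceptor is not required to hold the number in this pair. No measured evidence is available to explain this result.

From the compounds shown here alone, whether any group at this position can move the number beyond the scatter remains open. An amine, a carboxylic acid or a longer alkoxy chain in place of ethoxy would test this, since all the groups shown so far leave the numbers within the scatter of each other.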